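The compounds below may be only part of what the source reports. "The series", "measured", "known", "first", "only" and "open" are said of these compounds alone.

Measured in a physicochemical assay for lipophilicity, read by HPLC, in phosphate buffer, measured as octanol-water partition, at pH 7.4, tested at 100 uM; a lower number here means a more polar compound, a higher number a more lipophilic compound:
Compound 1 `CCOc1cc(C)c(-c2cccc(CNc3ccc(OCC(=O)O)cc3)c2)c(C)c1`: "not determined" (no result reported)
Compound 2 `O=C(O)COc1ccc(NCc2cccc(-c3ccccc3F)c2)cc1F`: 2.36

For the measured compounds named here, with no result reported for compound 1, compound 2 gives the only number, 2.36, so it cannot yet be ranked against anything. Compound 3 `Cc1ccccc1-c1cccc(CNc2ccc(OCC(=O)O)c(F)c2)c1` follows from compound 2 by one change, methyl in place of fluoro on an aromatic carbon. Going by the values given here, no measured pair shows what this swap does in this assay, so the expectation is tentative: a small upward step, near the edge of the usual scatter. The expected step is a number 0.24 log units higher from compound 2 to compound 3 (within the scatter). For compound 3 the estimated value is 2.6, with an expected range of 2.2 to 3.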

Compound 3, distribution coefficient: 2.41
For compound 3 the middle estimate is 0.19 log units above the measured one; measured number inside the range.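

For the compounds shown here, the first measured pair for this swap, methyl in place of fluoro on an aromatic carbon ortho to a large group, gives a number 0.05 log units higher from compound 2 to compound 3 (within the scatter) in this assay. At this position, then, the two groups cannot be told apart by this measurement, and 2-fluorophenyl and 2-methylphenyl read alike. No measurement shown here accounts for this result.

As far as these compounds go, whether a larger change at the same place, such as a nitrile or an amine, would shift the number remains open. So does whether this swap would behave the same way on another core.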